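Adding a cyano group to compound 3

A few compounds are considered here, and "the series" means these few. Any claim that something is new, unique, unknown or untested is made for them only; others in the source may bear on it.

compound 1 `COC(=O)Nc1cc(-c2ccc(OC[C@@](C)(N)CC(C)C)c(C)c2)ccn1`: 75%
compound 2 `COC(=O)Nc1cc(-c2cnc(OC[C@@](C)(N)CC(C)C)c(Cl)c2)ccn1`: 65%
compound 3 `COC(=O)Nc1cc(-c2ccc(OC[C@@](C)(N)CC(C)C)nc2)ccn1`: 79%

These numbers come from an ADME assay on microsomes from liver (Mus musculus) for metabolic stability, read by LC-MS, using NADPH, with a stated time of 10 min, tested at 0.5 uM; a lower number here means that less of the compound is left, a higher number that more of the compound is left. Compound 3 gives 79%, and this lies within the usual scatter of compound 1, which gives 75%. Compound 2 gives 65%, which is lower than compound 3 by more than the scatter.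

The next compound, compound 4 `COC(=O)Nc1cc(-c2cnc(OC[C@@](C)(N)CC(C)C)c(C#N)c2)ccn1`, is compound 3 with one change, cyano in place of hydrogen on an aromatic carbon.

Within the data shown here, only one measured step bears on this change. Replacing chloro with hydrogen on an aromatic carbon gave a number 14 percentage points higher from compound 2 to compound 3 (beyond the scatter). Among the measured compounds shown here, compound 4 goes the other way, with a group replacing hydrogen, so a modest fall of similar size is the best guide, although cyano is not chloro and no measured compound carries it. The expected change is a number 12 percentage points lower from compound 3 to compound 4 (beyond the scatter). Compound 4 is estimated at 67%, with an expected range from 53% to 80%.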

Compound 4, percent of the compound remaining: 86%
Compound 4: the middle estimate sits 19 percentage points below what was measured; the measured number lies above the stated range.
By their numbers in this assay, from the lowest: compounds 2, 1, 3 and 4 (each within the scatter of the next, the first and the last beyond it).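

In this assay, cyano on the aromatic carbon ortho to a (2-amino-2,4-dimethylpentyl)oxy group gives a number 7 percentage points higher from compound 3 to compound 4 (within the scatter), so this position can carry a group of 2 heavy atoms with no change beyond the scatter. The earlier compounds shown here showed only chloro at this carbon, with a number 14 percentage points higher from compound 2 to compound 3 (beyond the scatter) on its removal, and the new comparison gives a number 21 percentage points higher from compound 2 to compound 4 (beyond the scatter), so the drop seen with chloro does not carry over to every group placed here. No supporting measurement explains this difference between chloro and cyano.

The compounds shown leave open how other groups at this carbon, such as fluoro, methoxy or an amine, would behave. They also leave open whether cyano would give a similar result in the core of compound 1.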